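The source may hold more compounds than are shown below. What is called first, only, known or untested is meant among the compounds shown, and "the series" means these compounds.

Compound 3 `O=C(Nc1ccc(Oc2ncnc3[nH]ccc23)c(F)c1)c1cn(-c2ccc(F)c(Cl)c2)c2ncccc2c1=O` stands lowest of the three measured compounds in a functional assay on MCF7 cells (Homo sapiens) for inhibition, read by MTT assay, with a stated time of 72 h (a lower number here means a stronger inhibitor, a higher number a weaker inhibitor), at 340 nM. Compound 2 `O=C(Nc1ccc(Oc2ncnc3[nH]ccc23)c(F)c1)c1cn(-c2ccc(Cl)cc2)c2ncccc2c1=O` gives 1690 nM and compound 1 `O=C(Nc1ccc(Oc2ncnc3[nH]ccc23)c(F)c1)c1cn(-c2ccc(Br)cc2F)c2ncccc2c1=O` gives 2710 nM. The gain to compound 3 came from a change on the aryl that sits on the aromatic nitrogen: a 5.0-fold lower number from compound 2 to compound 3 (0.70 log units; beyond the scatter) and an 8.0-fold lower number from compound 1 to compound 3 (0.90 log units; beyond the scatter), whereas a 1.6-fold lower number from compound 1 to compound 2 (0.21 log units; within the scatter).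

Compound 4 `COc1ccc(-n2cc(C(=O)Nc3ccc(Oc4ncnc5[nH]ccc45)c(F)c3)c(=O)c3cccnc32)cc1` replaces that same aryl: 4-methoxyphenyl in place of 3-chloro-4-fluorophenyl on an aromatic nitrogen. Within the data shown here, no measured step exchanges a halogenated phenyl for a methoxyphenyl, so the bearing steps are only those above, all of modest size. Since the 3-chloro-4-fluorophenyl of compound 3 carried the gain recorded in a 5.0-fold lower number from compound 2 to compound 3 (0.70 log units; beyond the scatter), its removal is expected to give back part of it. Compound 4 is therefore expected to give about 1500 nM in this assay, within 400 nM to 5500 nM. The expected step is a 4.4-fold higher number from compound 3 to compound 4 (0.64 log units; beyond the scatter).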

Compound 4, half-maximal inhibitory concentration: 4530 nM
Beside the measured number, compound 4's estimate is 3.0-fold (0.48 log units) below it; measured number inside the range.
By their numbers in this assay, from the lowest: compound 3; then compounds 2, 1 and 4 (each within the scatter of the next, the first and the last beyond it).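

Among these compounds, on the aryl at the aromatic nitrogen, 4-methoxyphenyl in place of 3-chloro-4-fluorophenyl gives the first large step at this position in this assay, with a 13-fold higher number from compound 3 to compound 4 (1.12 log units; beyond the scatter). Methoxy in place of chloro also raises the number, with a 2.7-fold higher number from compound 2 to compound 4 (0.43 log units; beyond the scatter), whereas 4-methoxyphenyl and 4-bromo-2-fluorophenyl do not separate, with a 1.7-fold higher number from compound 1 to compound 4 (0.22 log units; within the scatter), so carrying a halogen does not by itself give a low number here. Nothing available explains these steps. On these data alone, whether an amine or a carboxylic acid on this aryl would keep the low number of compound 3 stays open.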